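Triazole for Imidazole on a Potent Chemokine Receptor Ligand

The compounds below may be only part of what the source reports. "The series", "measured", "known", "first", "only" and "open" are said of these compounds alone.

Among the three compounds measured in an assay on isolated protein for binding affinity to C-X-C chemokine receptor type 3 (Homo sapiens) (on this read-out higher numbers stand for weaker inhibition and lower numbers for stronger inhibition), compound 3 `CC[C@H]1CN(c2ncc(-c3ncc[nH]3)nc2C)[C@H](C)CN1C1CCN(C(=O)c2ccc(Cl)cc2)CC1` gives 1.6 nM, the lowest of the three numbers. Its nearest neighbour is compound 2 `CC[C@H]1CN(c2ncc(-c3ncc[nH]3)nc2C)[C@H](C)CN1C1CCN(C(=O)c2ccc(Cl)nc2N)CC1`, which gives 1.8 nM in this assay; the step of a 1.1-fold lower number from compound 2 to compound 3 (0.05 log units; within the scatter) lies within the scatter. Compound 1 `CC[C@H]1CN(c2ncc(-c3noc(=O)[nH]3)cc2Cl)CCN1C1CCN(Cc2ccc(Cl)cc2F)CC1`, built on a different core, gives 760 nM in this assay, far above the other two.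

Compound 4 `CC[C@H]1CN(c2ncc(-c3nnc[nH]3)nc2C)[C@H](C)CN1C1CCN(C(=O)c2ccc(Cl)cc2)CC1` differs from compound 3 in one place: 4H-1,2,4-triazol-3-yl in place of 1H-imidazol-2-yl on an aromatic carbon. Among the measured compounds shown here, no measured step touches this ring; the only step in the set, from compound 2 to compound 3, concerns the aryl group on the carbonyl carbon and was within the scatter. The swap keeps ring size, heavy-atom count and the single hydrogen-bond donor, adding one ring nitrogen and one acceptor. With nothing in the data pointing either way, the author expects compound 4 to remain close to compound 3, with a step of a 1.6-fold higher number from compound 3 to compound 4 (0.19 log units; within the scatter) that is not beyond the scatter. The estimate for compound 4 in this assay is 2.5 nM, with a range from 0.8 nM to 8 nM.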

Compound 4, half-maximal inhibitory concentration: 33.8 nM
The estimate for compound 4 lay 14-fold (1.13 log units) below the measured number; measured number outside the range, above it.
By their numbers in this assay, from the lowest: compounds 3 and 2 (each within the scatter of the next); then compound 4; then compound 1.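

In this assay the step of a 21-fold higher number from compound 3 to compound 4 (1.32 log units; beyond the scatter) is large and lies beyond the scatter, which shows that the read-out depends on which ring sits on this aromatic carbon. Among the compounds shown here, the only earlier step, a 1.1-fold lower number from compound 2 to compound 3 (0.05 log units; within the scatter), lay within the scatter and concerned the aryl group on the carbonyl carbon, whereas here the ring keeps its 5 heavy atoms and 1 hydrogen-bond donor and the change still produces a step beyond the scatter. Nothing shown gives a reason for this step.

The compounds shown leave open whether a 1H-pyrazol-3-yl ring, a tetrazole or an open-chain amide on this carbon would stay close to compound 3 or fall towards compound 4. They also leave open whether the same ring change would carry over to compound 2 with its 2-amino-6-chloropyridin-3-yl group.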